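A few compounds are considered here, and "the series" means these few. Any claim that something is new, unique, unknown or untested is made for them only; others in the source may bear on it.

Measured so far:
compound 1, `CC(C)n1cnc2c(Nc3ccccc3)nc(NCOCc3ccc(C(=O)Nc4ccccc4N)cc3)nc21`, in a functional assay on HepG2 cells (Homo sapiens) for antiproliferative activity, read by CCK-8 assay, with a stated time of 72 h, tested at 2 uM (a higher number here means a stronger effect of the compound at the concentration tested, a lower number a weaker effect), compound 1 gives 6.58%
compound 2, `Cc1ccc(Nc2nc(Cl)nc3c2ncn3Cc2ccc(C(=O)Nc3ccccc3N)cc2)cc1`, in this assay compound 2 gives 76.2%
compound 3, `Cc1ccc(Nc2nc(Cl)nc3c2ncn3Cc2ccc(/C=C/C(=O)Nc3ccccc3N)cc2)cc1`, in this assay compound 3 gives 33.6%

Within the data shown here, compound 2 stands highest of the three numbers; compound 3 lies lower, a number 42.6 percentage points lower from compound 2 to compound 3 (beyond the scatter), and compound 1 lies further below, though compound 1 differs from compound 2 in several places at once, so no single step is drawn from that pair.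

Compound 4, `Nc1ccccc1NC(=O)c1ccc(Cn2cnc3c(NCc4ccccc4)nc(Cl)nc32)cc1`, is not yet measured. (benzyl in place of 4-methylphenyl on a nitrogen on an aromatic ring). Among the measured compounds shown here, the only measured step, a number 42.6 percentage points lower from compound 2 to compound 3 (beyond the scatter), alters the (2-aminophenyl)carbamoyl end and so does not bear on the nitrogen carrying the 4-methylphenyl; no measured pair changes that group alone. Compound 1, which carries a plain phenyl on that nitrogen among its other differences, gives 6.58%, the nearest hint and one pointing downward without sizing the step. The step to compound 4 is therefore expected to be a drop of uncertain size, a number 26.2 percentage points lower from compound 2 to compound 4 (beyond the scatter). For compound 4 the estimate is 50%, expected to lie between 15% and 80%.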

Compound 4, a percentage reported as inhibition, at one concentration (the size of the read-out at that concentration, not a potency): 7.55%
Estimate against measurement, compound 4: 42.5 percentage points above, and the stated range ends above it.
By their numbers in this assay, from the lowest: compounds 1 and 4 (each within the scatter of the next); then compound 3; then compound 2.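

In this assay, a number 68.7 percentage points lower from compound 2 to compound 4 (beyond the scatter) with benzyl in place of 4-methylphenyl on a nitrogen on an aromatic ring, so this position does not tolerate the change at the concentration tested. The two groups have the same count of heavy atoms, all carbon, and each holds one six-membered aromatic ring, so a large change in the read-out occurs here with no change in atom content and only a different joining of those atoms. No measurement at hand accounts for the drop. Still open, on these data alone, is whether the read-out follows the methyl group or the way the ring is attached to the nitrogen, which 4-methylbenzyl on that nitrogen would address. Also open, as far as these compounds go, is how a longer chain, such as 2-phenylethyl, would read there.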